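The compounds below may be only part of what the source reports. "The series", "measured", "known", "first", "only" and "open" are said of these compounds alone.

Compound 1, `COc1ccc2ncc(S(=O)(=O)c3ccc(F)cc3)c(N3CCC(C)CC3)c2c1`, gives 27% in an assay on isolated protein for displacement of a labelled ligand from metabotropic glutamate receptor 5 (Homo sapiens), with a stated time of 60 min, tested at 1 uM; a lower number here means less inhibition, a higher number more inhibition at the concentration tested (going by the name of the read-out).
Compound 2, `CC1CCN(c2c(S(=O)(=O)c3ccc(F)cc3)cnc3cc(F)ccc23)CC1`, gives 74.5% in this assay.
Compound 3, `COc1cccc(S(=O)(=O)c2cnc3ccc(OC)cc3c2N2CCC(C)CC2)c1`, gives 0% in this assay.

Compound 2 shows the highest number of the three, and its steps to the other two both lie beyond the scatter. Compound 1 and compound 3 differ in a single place: 3-methoxyphenyl in place of 4-fluorophenyl on a sulfonyl sulfur. That change produced a number 27 percentage points lower from compound 1 to compound 3 (beyond the scatter). Compound 2 and compound 1 differ in more than one place; the difference between the two cores is not broken down here.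

Compound 4, `COc1cccc(S(=O)(=O)c2cnc3cc(F)ccc3c2N2CCC(C)CC2)c1`, has not yet been measured in this assay. It differs from compound 2 by 3-methoxyphenyl in place of 4-fluorophenyl on a sulfonyl sulfur, and the place of the change is described in the same words as for the pair compound 1 and compound 3, so this is the same change made on a different core. Because the earlier instance gave a number 27 percentage points lower from compound 1 to compound 3 (beyond the scatter), a fall of comparable size is expected on the core of compound 2, although the higher starting point leaves more room for the number to move than compound 1 had. Compound 4 is therefore estimated to give 40% in this assay, with a likely range from 15% to 65%. The expected step is a number 34.5 percentage points lower from compound 2 to compound 4 (beyond the scatter).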

Compound 4, a percentage reported as inhibition, at one concentration (the size of the read-out at that concentration, not a potency): 90%
For compound 4 the middle estimate is 50 percentage points below the measured one, and the stated range ends below it.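

On the core of compound 2, 3-methoxyphenyl in place of 4-fluorophenyl on a sulfonyl sulfur gave a number 15.5 percentage points higher from compound 2 to compound 4 (beyond the scatter) in this assay. Set beside the earlier instance, the same change did not carry over from one core to the other, in direction or in size: the same change on two cores in this assay, a number 27 percentage points lower (beyond the scatter) from compound 1 to compound 3 and a number 15.5 percentage points higher (beyond the scatter) from compound 2 to compound 4, 42.5 percentage points apart, beyond the scatter of two such steps. Within the data shown here, this shows that in these two pairs the outcome of the change depends on the core it is made on, so the result on one core was a poor guide to the other, but it does not show which feature of the cores matters, as the cores of compound 1 and compound 2 differ in more than one place and only two pairs are available.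

The compounds shown leave open how the change would behave on any further core, and whether a phenyl ring carrying an amine or a carboxylic acid on the sulfonyl sulfur would follow either pair. They also leave open how these single-concentration numbers would translate into potency.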